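Nitrogen substituent swap from compound 1 to compound 3

The source may hold more compounds than are shown below. What is called first, only, known or untested is meant among the compounds shown, and "the series" means these compounds.

Series notes begin with compound 1 `Cc1ccc(-n2cc(C(=O)O)c(=O)c3c(O)c(Cc4cccc(Cl)c4F)ccc32)cc1` and compound 2 `O=C(O)c1cn(Cc2ccccc2)c2ccc(Cc3ccccc3F)c(O)c2c1=O`, the only two members with numbers so far. In an ADME assay on C8166 cells (Homo sapiens) for cytotoxicity, read by MTT assay (on this read-out higher numbers stand for lower toxicity in this test and lower numbers for higher toxicity in this test), compound 1 gives 194000 nM and compound 2 gives 156000 nM. These two values lie within the scatter of each other, so compound 1 stands level with compound 2 on the present evidence.

The next member is compound 3 `O=C(O)c1cn(Cc2cccc(F)c2)c2ccc(Cc3cccc(Cl)c3F)c(O)c2c1=O`. It carries 3-fluorobenzyl in place of the 4-methylphenyl of compound 1 on an aromatic nitrogen (3-fluorobenzyl in place of 4-methylphenyl on an aromatic nitrogen), and the rest of the core of compound 1 is kept.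

For the measured compounds named here, no measured pair differs in one place only, so no direct precedent exists for this change. Going by the values given here, the only guide is the pair of values already in hand, compound 1 at 194000 nM and compound 2 at 156000 nM, which sit within the scatter. No change beyond the scatter is therefore expected in this assay, and the estimated step is a 1.3-fold lower number from compound 1 to compound 3 (0.11 log units; within the scatter). For compound 3 the expected value is 150000 nM, with an estimated range of 60000 nM to 320000 nM.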

Compound 3, half-maximal cytotoxic concentration: 69000 nM
For compound 3 the middle estimate is 2.2-fold (0.34 log units) above the measured one, within the range that was stated.
By their numbers in this assay, from the lowest: compound 3; then compounds 2 and 1 (each within the scatter of the next).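

In this assay, a 2.8-fold lower number from compound 1 to compound 3 (0.45 log units; beyond the scatter) gives the series its first single-place step, showing that the group on the aromatic nitrogen can shift this read-out beyond the scatter, here towards higher toxicity in this test. The entering 3-fluorobenzyl differs from the leaving 4-methylphenyl both in the substituent on the ring and in the carbon link to the nitrogen, so this one modest step covers both differences and cannot be assigned to either. Nothing measured here gives a reason for the step.

Open, from the compounds shown here alone, is which of the two differences carries the step, a question that a plain benzyl or a 4-methylbenzyl group on the nitrogen, with the rest of compound 3 kept, would help to settle. Also open, going by these compounds, is whether the read-out responds in the same way to nitrogen substituents without an aromatic ring, such as a propyl chain or a longer chain ending in an amine.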